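A few compounds are considered here, and "the series" means these few. Any claim that something is new, unique, unknown or untested is made for them only; others in the source may bear on it.

Measured so far in a functional assay on HT-29 cells (Homo sapiens) for antiproliferative activity, read by MTT assay, with a stated time of 48 h; a higher number here means a weaker inhibitor, a lower number a stronger inhibitor:

Compound 1 `O=C(Nc1ccc(OC(=O)c2cc3cc([N+](=O)[O-])ccc3s2)cc1)Nc1ccc(Oc2ccccc2)cc1` gives 13300 nM.
Compound 2 `O=C(Nc1ccccc1)Nc1ccc(OC(=O)c2ccc([N+](=O)[O-])cc2)cc1` gives 185000 nM.
Compound 3 `O=C(Nc1ccccc1)Nc1ccc(OC(=O)c2ccc(F)cc2)cc1` gives 128000 nM.

Compound 3 stands second highest of the three numbers in this assay. Its nearest neighbour is compound 2, the farthest compound 1; the step of a 1.4-fold lower number from compound 2 to compound 3 (0.16 log units; within the scatter) is the only one in which a single group is exchanged, and the gap from compound 1 to compound 3 is beyond the scatter.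

Compound 4 `COc1ccc(C(=O)Oc2ccc(NC(=O)Nc3ccccc3)cc2)cc1` is the next member: methoxy in place of fluoro on an aromatic carbon. Among the compounds with values here, the one measured step that bears on this change is the exchange at the same group, a 1.4-fold lower number from compound 2 to compound 3 (0.16 log units; within the scatter), which stayed within the scatter. Nothing in the measured set shows that swapping this group moves the number beyond the scatter, so for compound 4 the expected step is a 1.1-fold lower number from compound 3 to compound 4 (0.03 log units; within the scatter), with no clear direction.

For compound 4 in this assay the estimate is 120000 nM, expected to lie between 40000 nM and 350000 nM.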

Compound 4, half-maximal inhibitory concentration: 175000 nM
Estimate against measurement, compound 4: 1.5-fold (0.16 log units) below, and the stated range covers the measured number.
By their numbers in this assay, from the lowest: compound 1; then compounds 3, 4 and 2 (each within the scatter of the next).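

In this assay, the change from 4-fluorophenyl to 4-methoxyphenyl, on an aromatic carbon para to a large group, gives a 1.4-fold higher number from compound 3 to compound 4 (0.14 log units; within the scatter). With a 1.1-fold lower number from compound 2 to compound 4 (0.02 log units; within the scatter), all three pairs among nitro, fluoro and methoxy at this position are now read, and each pair lies within the scatter, so methoxy, the larger group with a hydrogen-bond acceptor, joins a flat set of three rather than a single exchange. No evidence on hand offers an explanation for this flat result.

As far as these compounds go, whether an amine, a carboxylic acid or a longer chain at this position would move the number beyond the scatter remains open. Also open, from the compounds shown here alone, is whether these same exchanges would stay as flat on the core of compound 1.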